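This account rests on a few compounds, and the source may have more. Where it says the series, first, only, none or still open, it means among the compounds named here.

Measured in a functional assay on CCRF-CEM cells (Homo sapiens); a lower number here means a stronger inhibitor, a higher number a weaker inhibitor:
- compound 1 `Cc1ccc(-c2ncnc3c2ncn3C[C@@H]2C[C@H](CO)c3ccccc32)cc1`: 1.4 ug/mL
- compound 2 `COc1ncnc2c1ncn2C[C@@H]1C[C@H](CO)c2ccccc21`: 24 ug/mL
- compound 3 `Cc1cn(C[C@@H]2C[C@H](CO)c3ccccc32)c(=O)[nH]c1=O`: 81 ug/mL

Compound 1 has the lowest number of the three in this assay, with compound 2 and compound 3 both higher by more than the scatter. Compound 4 `OC[C@H]1C[C@@H](Cn2cnc3c(NC4CC4)ncnc32)c2ccccc21` is not yet measured. It departs from compound 1 by one change, cyclopropylamino in place of 4-methylphenyl on an aromatic carbon. Within the data shown here, one measured step bears on this, the loss of the same 4-methylphenyl to methoxy, and it was large: a 17-fold higher number from compound 1 to compound 2 (1.23 log units; beyond the scatter). Among the measured compounds shown here, compound 3 differs in more than one place and offers no such step. For the measured compounds named here, no measured compound carries cyclopropylamino, so a rise of similar size is expected, with wide uncertainty. The expected step is an 8.6-fold higher number from compound 1 to compound 4 (0.93 log units; beyond the scatter). Compound 4 is estimated at 12 ug/mL, with a range of 3.5 ug/mL to 40 ug/mL.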

Compound 4, half-maximal inhibitory concentration: 24 ug/mL
For compound 4 the middle estimate is 2.0-fold (0.30 log units) below the measured one; the measured number falls inside the stated range.
By their numbers in this assay, from the lowest: compound 1; then compounds 2 and 4 (each within the scatter of the next); then compound 3.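

In this assay, cyclopropylamino in place of 4-methylphenyl gives a large step, a 17-fold higher number from compound 1 to compound 4 (1.23 log units; beyond the scatter). Comparing the two replacements gives no change at the digits printed from compound 2 to compound 4 (within the scatter), so at this position cyclopropylamino and methoxy cannot be told apart, and both stand well away from 4-methylphenyl. Nothing measured here accounts for this.

The compounds shown leave open whether the low number of compound 1 needs the methyl group, as an unsubstituted phenyl would test, or an all-carbon ring, as a pyridyl would test.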